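This account rests on a few compounds, and the source may have more. Where it says the series, first, only, none or still open, it means among the compounds named here.

Measured so far in a functional assay on DU-145 cells (Homo sapiens) for inhibition, read by trypan blue exclusion, with a stated time of 96 h; on this read-out lower numbers stand for stronger inhibition of growth and higher numbers for weaker inhibition of growth:
compound 2 `O=C(O)c1ccc(C(=O)/C(=C\c2ccc(Br)cc2)SCc2ccc(Br)cc2)cc1` — 1000 nM
compound 1 `O=C(/C(=C\c1ccc(O)cc1O)SCc1cccc(Cl)c1)c1ccc(Br)cc1` — 50000 nM
compound 3 `O=C(O)c1ccc(C(=O)/C(=C\c2ccc(Br)cc2)SCc2ccc(F)cc2)cc1` — > 100000 nM; this is a limit of the assay, not a number.

Compound 2 gives the lowest of the two numbers, and compound 1 stands higher, beyond the scatter. Compound 4 `O=C(O)c1ccc(C(=O)/C(=C\c2ccc(O)c([N+](=O)[O-])c2)SCc2ccc(Br)cc2)cc1` differs from compound 2 in one place: 4-hydroxy-3-nitrophenyl in place of 4-bromophenyl on a double-bonded chain carbon bound to a double-bonded chain carbon. For the measured compounds named here, only one measured step bears on it, and it changes a different ring: an at least 100-fold higher number from compound 2 to compound 3 (2.00 log units; beyond the scatter). That step rests on a limit (the limit of > 100000 nM in this assay, at which 1 of the 3 values shown sits). Loss of a bromine on an aromatic ring has so far gone with a large rise; the present change also removes a ring bromine, while adding hydroxy and nitro. A rise is therefore expected, a 20-fold higher number from compound 2 to compound 4 (1.30 log units; beyond the scatter). Compound 4 is estimated at 20000 nM, expected between 3000 nM and 100000 nM.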

Compound 4, concentration for 50% growth inhibition: 50000 nM
Estimate against measurement, compound 4: 2.5-fold (0.40 log units) below; the measured number falls inside the stated range.
By their numbers in this assay, from the lowest: compound 2; then compounds 1 and 4 (each within the scatter of the next). At a limit, above all of these: compound 3.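

The change at this position gives a 50-fold higher number from compound 2 to compound 4 (1.70 log units; beyond the scatter) in this assay and so shows that the group on a double-bonded chain carbon bound to a double-bonded chain carbon also matters, not only the ring changed in compound 3. This step rests on two numbers. Compound 3 remains a limit of the assay: the limit of > 100000 nM in this assay, at which 1 of the 4 values shown sits.

On these data alone, whether the rise follows the loss of the 4-bromophenyl group or the entry of the hydroxy or nitro group stays open, as these changes occur together. As far as these compounds go, how an amine on this ring would compare with the bromine of compound 2 also stays open.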